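This account rests on a few compounds, and the source may have more. Where it says the series, first, only, none or still open, it means among the compounds named here.

Measured so far:
compound 1, `CC(C)CC/N=C(\NC#N)Nc1cccnc1`: 20 mg/kg
compound 2, `CCCCC(CC)C/N=C(\NC#N)Nc1cccnc1`: > 50 mg/kg
compound 3, `CC(C)CC(C)/N=C(\NC#N)Nc1ccncc1`: 35 mg/kg

In a functional assay on the whole organism (blood, strain Wistar-Okamoto) with Rattus norvegicus as the target, with a stated time of 5 days (a lower number here means that less compound is needed, a higher number that more compound is needed for the effect), compound 3 gives 35 mg/kg, the highest of the two numbers reported. The nearest is compound 1, which gives 20 mg/kg, and the gap between them sits within the scatter, so no order can be read from the two. For compound 2 the result is not a number but a limit of the assay, > 50 mg/kg. That is the only limit among the three results, as shown by the limit of > 50 mg/kg in this assay, at which 1 of the 3 values shown sits.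

The step followed here leads from compound 3 to compound 4, `CC(/N=C(\NC#N)Nc1ccncc1)C1CC1`, which has not yet been measured. The change is cyclopropyl in place of isobutyl on a saturated chain carbon bound to a double-bonded nitrogen and a saturated chain carbon. Among the measured compounds shown here, no pair of measured compounds shows this kind of change, so its size has to be guessed from the structures alone. The step from compound 3 to compound 4 is expected to stay small, in either direction, and most likely not beyond the scatter, which is the step meant by a 1.2-fold lower number from compound 3 to compound 4 (0.07 log units; within the scatter). For compound 4 the estimate in this assay is 30 mg/kg, with a range from 12 mg/kg to 80 mg/kg.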

Compound 4, minimum effective dose: 3 mg/kg
Beside the measured number, compound 4's estimate is 10-fold (1.00 log units) above it, outside the stated range (below it).
By their numbers in this assay, from the lowest: compound 4; then compounds 1 and 3 (each within the scatter of the next). At a limit, above all of these: compound 2.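

In this assay, the exchange of isobutyl for cyclopropyl on a saturated chain carbon bound to a double-bonded nitrogen and a saturated chain carbon gives a 12-fold lower number from compound 3 to compound 4 (1.07 log units; beyond the scatter). This is the first pair among the compounds shown that differs in one place only, and it shows that the group at this position can shift the required dose well beyond the scatter. The change is also one between two all-carbon groups, with no hydrogen-bond donor or acceptor and no net charge on either side, and the entering group brings a three-membered non-aromatic ring where the leaving group has no ring; nothing measured here gives a reason for the size of this step.

As far as these compounds go, a single step cannot separate the effect of the ring from that of the shorter group, so it remains open how cyclobutyl, a tert-butyl group or a longer chain would fare at this place, or an amine or a carboxylic acid carried on the same carbon. From the compounds shown here alone, it also remains open whether cyclopropyl would have a comparable effect on the core of compound 1.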